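This account rests on a few compounds, and the source may have more. Where it says the series, first, only, none or still open, it means among the compounds named here.

Working notes on the series. In an ADME assay on MT4 cells (Homo sapiens) for cytotoxicity, read by MTT assay, with a stated time of 4 days (a higher number here means that more compound is tolerated, a lower number that less compound is tolerated), compound 1 `COc1ccccc1Oc1nc(Nc2ccc(C#N)cc2)nc2ccccc12` gives 150000 nM. Compound 2 `COc1ccc(Oc2nc(Nc3ccc(C#N)cc3)nc3ccccc23)cc1` gives 340000 nM in this assay. Compound 3 `N#Cc1ccc(Nc2nc(Oc3ccc(Br)cc3)c3ccccc3n2)cc1` gives 215000 nM in this assay. Compound 3 thus stands second highest of the three numbers, and its distance to compound 1 as well as to compound 2 lies within the usual scatter. Compound 4 `N#Cc1ccc(Nc2nc(Oc3ccccc3)c3ccccc3n2)cc1` is the next compound for this assay; it differs from compound 3 by hydrogen in place of bromo on an aromatic carbon. For the measured compounds named here, two measured steps bear on this position: a 1.6-fold lower number from compound 2 to compound 3 (0.20 log units; within the scatter) and a 1.4-fold higher number from compound 1 to compound 3 (0.16 log units; within the scatter), both within the scatter. Going by the values given here, the only step beyond the scatter, a 2.3-fold higher number from compound 1 to compound 2 (0.36 log units; beyond the scatter), concerns a change at a different position. Exchanging the group on this aromatic carbon has so far moved the number little, so no step beyond the scatter is expected from compound 3 to compound 4; the expected step is a 1.1-fold lower number from compound 3 to compound 4 (0.03 log units; within the scatter). Compound 4 is estimated at 200000 nM in this assay, with a range of 100000 nM to 400000 nM.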

Compound 4, half-maximal cytotoxic concentration: 370000 nM
Compound 4: the middle estimate sits 1.9-fold (0.27 log units) below what was measured; the measured number falls inside the stated range.
By their numbers in this assay, from the lowest: compounds 1, 3, 2 and 4 (each within the scatter of the next, the first and the last beyond it).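

With the bare phenoxy group of compound 4 as reference, the para place on the phenyl ring shows no step beyond the scatter on removing either group: bromo (a 1.7-fold higher number from compound 3 to compound 4 (0.24 log units; within the scatter)) or methoxy (a 1.1-fold higher number from compound 2 to compound 4 (0.04 log units; within the scatter)). The same exchange from the 2-methoxyphenyl group does pass the scatter (a 2.5-fold higher number from compound 1 to compound 4 (0.39 log units; beyond the scatter)), so the two methoxy compounds give different readings against hydrogen, although compound 3 stays within the scatter of compound 1. No measurement on hand accounts for these steps.

Only bromo and methoxy have been compared with hydrogen at the para place, so an amine, a carboxylic acid or a longer chain there could behave differently. For the compounds shown here, the 2-methoxyphenyl group is also the only group of its kind here, so whether a 2-bromophenyl group would give a similar step remains open.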